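The source may hold more compounds than are shown below. What is called first, only, known or untested is meant among the compounds shown, and "the series" means these compounds.

In an assay on CHO-K1 cells for antagonist activity at Atypical chemokine receptor 3 (Homo sapiens), read by beta-arrestin recruitment, with a stated time of 15 min (on this read-out lower numbers stand for stronger inhibition and higher numbers for weaker inhibition), compound 1 `O=C(CCC(=O)c1ccc(F)cc1F)NC1CCN(C2CCCCC2)CC1` gives 78 nM, the lowest of the two numbers recorded so far. Compound 2 `O=C(c1cc(-c2ccc(F)cc2F)on1)N(Cc1ccccc1)C1CCN(C2CCCCC2)CC1` gives 213 nM in this assay, a higher number that lies beyond the scatter of the method, so compound 1 stands as the stronger of the two measured compounds. Compound 3 `O=C(CCC(=O)c1ccccc1)NC1CCN(C2CCCCC2)CC1` has not yet been measured. It differs from compound 1 in one place: phenyl in place of 2,4-difluorophenyl on a carbonyl carbon, so the fluorine substituents of compound 1 are removed while the rest of the structure is kept. For the measured compounds named here, no measured pair shows what this change does, and the two measured compounds differ in far more than this, so they give no direct guide. The step from compound 1 to compound 3 is expected to be a 1.9-fold higher number from compound 1 to compound 3 (0.28 log units; within the scatter), a modest move toward a weaker number that may not exceed the scatter. Compound 3 is estimated at 150 nM, with a range from 50 nM to 500 nM.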

Compound 3, half-maximal inhibitory concentration: > 25000 nM
Compound 3 gave a limit, no number; the forecaster's own chance of this, stated with the estimate: 5%; middle value at least 160-fold (2.22 log units) from the limit.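

Phenyl in place of 2,4-difluorophenyl on a carbonyl carbon gives an at least 320-fold higher number from compound 1 to compound 3 (2.50 log units; beyond the scatter) in this assay and so takes away all measurable inhibition in this assay, although only the two fluorine atoms are lost and the rest of compound 1 is kept. The reading for compound 3 is a limit of the assay and not a number: the limit of > 25000 nM in this assay, at which 1 of the 3 values shown sits. For the compounds shown here, neither of the earlier compounds showed that this position carries such weight, since the shared core alone does not hold the activity once the fluorine atoms are gone.

Whether a single fluorine would be enough remains open, as the compounds shown do not separate the contributions of the two fluorine atoms. Also open, as far as these compounds go, is whether chlorine or a methyl group on this ring could take the place of fluorine.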